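This account rests on a few compounds, and the source may have more. Where it says the series, first, only, none or still open, it means among the compounds named here.

Compound 1 `CC(=O)OCCOn1cnc2c(Cl)nc(N)nc21` gives > 500000 nM in a functional assay on SW-620 cells (Homo sapiens) for inhibition; a lower number here means a stronger inhibitor, a higher number a weaker inhibitor. Compound 2 `CC(=O)OCCOn1cnc2c(Cl)nc(I)nc21` gives 15800 nM in this assay.

For compound 1 the value is a limit of the assay and not a number, so only a limit is known for it (the limit of > 500000 nM in this assay, at which 1 of the 2 values shown sits). Among the measured compounds shown here, the single measured step, an at least 31-fold lower number from compound 1 to compound 2 (1.50 log units; beyond the scatter), replaces the amino group by iodo and leaves the chloro untouched. Compound 3 `CC(=O)OCCOn1cnc2c(S)nc(N)nc21` differs from compound 1 in the other position: sulfanyl in place of chloro on an aromatic carbon, while the amino group that compound 1 carries stays in place. The measured step therefore does not bear directly on this change; what is shared with compound 3 is the amino group under which compound 1 sits at the limit. Compound 3 is accordingly expected to remain very weak, with a step of an at least 1.2-fold lower number from compound 1 to compound 3 (0.09 log units; that floor lies within the scatter). The estimate for compound 3 is 400000 nM, with a range from 50000 nM to 1000000 nM.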

Compound 3, half-maximal inhibitory concentration: 4200 nM
The estimate for compound 3 lay 95-fold (1.98 log units) above the measured number; the whole stated range lies above it.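

Exchanging chloro for sulfanyl while the amino group stays in place gives an at least 110-fold lower number from compound 1 to compound 3 (2.07 log units; beyond the scatter) in this assay, so the amino group alone does not hold a compound at the bottom of the range of this assay, and the position carrying chloro also governs the read-out. The size of this step is only a floor, because compound 1 has a limit of the assay and not a number: the limit of > 500000 nM in this assay, at which 1 of the 3 values shown sits. Compound 2 and compound 3 differ in two places, so the shown changes at the two positions cannot be set against each other.

The compounds shown leave open whether the gain depends on the sulfur atom or on the hydrogen it carries, which a methylsulfanyl or a hydroxyl group at this position would separate. Also open, as far as these compounds go, is how sulfanyl behaves when iodo replaces the amino group in the same compound.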